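Swapping an amide for methoxy: expected effect on cytotoxicity

The source may report more compounds than this note shows. Statements on the series, on what has been measured and on what is new or still open speak of the compounds shown alone.

Measured compounds:
- compound 1 `O=C(c1ccc(NCc2cncn2Cc2ccc(-c3ccccc3)cc2)cc1-c1ccccc1)N1CCCCC1`: > 1000 nM
- compound 2 `COC(=O)c1ccc(NCc2cncn2Cc2ccccc2[N+](=O)[O-])cc1-c1ccccc1`: 10000 nM

Both results come from a toxicity assay on NIH3T3 cells (Mus musculus) for cytotoxicity, read by resazurin assay; on this read-out higher numbers stand for an effect only at larger amounts of compound and lower numbers for an effect already at smaller amounts. For compound 1 the value > 1000 nM is a limit of the assay rather than a measured number, so compound 1 stands at the limit of > 1000 nM in this assay, at which 1 of the 2 values shown sits, and no sharper value is known. Compound 2 gives 10000 nM, a number at the weak end of the scale. The unmeasured compound 3 `COc1ccc(NCc2cncn2Cc2ccc(-c3ccccc3)cc2)cc1-c1ccccc1` differs from compound 1 in one place: methoxy in place of (piperidin-1-yl)carbonyl on an aromatic carbon. The change is a methoxy in place of a larger amide-type group on the shared core. With the two measured compounds both showing an effect only at large amounts, the step is expected to stay within the usual scatter, as a step that the limit leaves unreadable from compound 1 to compound 3. Compound 3 is therefore estimated at 5000 nM, in the range 1000 nM to 30000 nM, quite possibly reported again only as a limit.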

Compound 3, half-maximal effective concentration: > 1000 nM
Compound 3 was reported as a limit; the forecaster's own chance of this, stated with the estimate: 60%; the middle value is on the limit's open side.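

Going by these compounds alone, compound 1 and compound 3 are both reported only as limits in this assay, and no step between them can be read. Left open is whether methoxy in place of (piperidin-1-yl)carbonyl changes cytotoxicity at all, and where the actual values of compound 1 and compound 3 lie.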